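Ring size at the chain amine: compound 3 to compound 4

A few compounds are considered here, and "the series" means these few. Any claim that something is new, unique, unknown or untested is made for them only; others in the source may bear on it.

Measured compounds:
compound 1 `COc1cc2c(Oc3ccc(NC(=O)c4nn(-c5ccccc5C)c(=O)cc4C)cc3F)ccnc2cc1OCCCN1CCCCC1` — 1920 nM
compound 2 `COc1cc2c(Oc3ccc(NC(=O)c4nn(-c5ccccc5C(F)(F)F)c(=O)cc4C)cc3F)ccnc2cc1OCCCN1CCCCC1` — 140 nM
compound 3 `COc1ccc(-n2nc(C(=O)Nc3ccc(Oc4ccnc5cc(OCCCN6CCCC6)c(OC)cc45)c(F)c3)c(C)cc2=O)cc1` — 2770 nM

In a functional assay on A549 cells (Homo sapiens) for inhibition, read by MTT assay, with a stated time of 72 h (on this read-out lower numbers stand for stronger inhibition and higher numbers for weaker inhibition), compound 3 gives the highest of the three numbers. Its nearest neighbour is compound 1, and the gap between them lies within the scatter, so the two cannot be ordered. Compound 2 stands far apart: the step of a 14-fold lower number from compound 1 to compound 2 (1.14 log units; beyond the scatter) is large and well beyond the scatter, and compound 3 lies even further from compound 2.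

Compound 4 `COc1ccc(-n2nc(C(=O)Nc3ccc(Oc4ccnc5cc(OCCCN6CCCCC6)c(OC)cc45)c(F)c3)c(C)cc2=O)cc1` has not yet been measured. It differs from compound 3 by piperidin-1-yl in place of pyrrolidin-1-yl on a saturated chain carbon, three bonds along the chain from an oxygen on an aromatic ring. Among the compounds with values here, no measured step bears on this change: the only step among the measured compounds, from compound 1 to compound 2, concerns trifluoromethyl in place of methyl on an aromatic carbon, and compounds 1 and 2 already carry the piperidin-1-yl group. Nothing in the measured set speaks for a change beyond the scatter from a five-membered to a six-membered saturated amine ring at this place. Compound 4 is therefore expected to stay close to compound 3, with an estimated step of a 1.1-fold lower number from compound 3 to compound 4 (0.04 log units; within the scatter). The estimate for compound 4 in this assay is 2500 nM, in a range from 1000 nM to 6500 nM.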

Compound 4, half-maximal inhibitory concentration: 1500 nM
Estimate against measurement, compound 4: 1.7-fold (0.22 log units) above; low and high end bracket the measured number.
By their numbers in this assay, from the lowest: compound 2; then compounds 4, 1 and 3 (each within the scatter of the next).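

In this assay, the exchange of pyrrolidin-1-yl for piperidin-1-yl on a saturated chain carbon, three bonds along the chain from an oxygen on an aromatic ring, can now be read directly: it gives a 1.8-fold lower number from compound 3 to compound 4 (0.27 log units; within the scatter), so the ring size at this place makes no clear difference here. With piperidin-1-yl held fixed, the group on the aromatic nitrogen gives two contrasting results: 4-methoxyphenyl in place of 2-methylphenyl gives a 1.3-fold lower number from compound 1 to compound 4 (0.11 log units; within the scatter), while 4-methoxyphenyl in place of 2-(trifluoromethyl)phenyl gives an 11-fold higher number from compound 2 to compound 4 (1.03 log units; beyond the scatter). No measurement at hand explains either result.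

The compounds shown leave open whether the ring exchange would stay as small with 2-(trifluoromethyl)phenyl on the aromatic nitrogen. They also leave open how a morpholine or a dimethylamino group at the end of the chain would read.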